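Swapping the aryl group on the amide carbonyl

This account rests on a few compounds, and the source may have more. Where it says the series, first, only, none or still open, it means among the compounds named here.

Compound 1, `CC(=O)Nc1cc2c(C3CCN(C)CC3)c[nH]c2cn1`, gives 210 nM in an assay for binding affinity to 5-hydroxytryptamine receptor 1F (Homo sapiens), read by radioligand binding; on this read-out lower numbers stand for stronger inhibition and higher numbers for weaker inhibition. Compound 2, `COc1ccccc1C(=O)Nc1ccc2[nH]cc(C3CCN(C)CC3)c2n1`, gives 20 nM in this assay.

Of the two numbers shown, compound 2 has the lower one, and compound 1 stands above it, beyond the scatter. Compound 3, `Cc1cccc(C(=O)Nc2ccc3[nH]cc(C4CCN(C)CC4)c3n2)c1`, carries 3-methylphenyl in place of 2-methoxyphenyl on a carbonyl carbon. Among the measured compounds shown here, no step of this kind has been measured here, so the direction is open; a modest loss within or just beyond the scatter seems the likeliest outcome. Compound 3 is therefore expected to give 40 nM, between 10 nM and 160 nM, which would mean an estimated step of a 2.0-fold higher number from compound 2 to compound 3 (0.30 log units; within the scatter).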

Compound 3, inhibition constant: 5.8 nM
For compound 3 the middle estimate is 6.9-fold (0.84 log units) above the measured one; measured number below the stated range.
By their numbers in this assay, from the lowest: compound 3; then compound 2; then compound 1.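

On the carbonyl carbon whose other neighbour is the amide-type nitrogen, the change to 3-methylphenyl from 2-methoxyphenyl gives a 3.4-fold lower number from compound 2 to compound 3 (0.54 log units; beyond the scatter) in this assay, beyond the scatter. The gain shows that this place responds to the aryl group it carries, and that a low number here does not depend on the 2-methoxyphenyl group. Nothing available here bears on why the number falls.

The compounds shown do not separate the arrival of the methyl group from the loss of the methoxy group, or either from where it sits on the ring. Going by these compounds, how an unsubstituted phenyl or a cyclohexyl group on the same carbonyl would compare remains open.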